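The compounds below may be only part of what the source reports. "The series", "measured", "known", "first", "only" and "open" are said of these compounds alone.

Working notes on the series.

Three compounds of the shared core have numbers in a functional assay on NUGC-3 cells (Homo sapiens) for cytotoxicity, read by sulforhodamine B assay, tested at 10 uM; a lower number here means less inhibition, a higher number more inhibition at the concentration tested (going by the name of the read-out). Compound 1 `CCCCc1ccc(-c2cc(-c3cn([C@H]4C[C@H](OC(C)=O)[C@@H](COC(C)=O)O4)c(=O)[nH]c3=O)on2)cc1` gives 39.8% in this assay. Compound 2 `CC(=O)OC[C@H]1O[C@@H](n2cc(-c3cn(Cc4ccc(C(C)(C)C)cc4)nn3)c(=O)[nH]c2=O)C[C@@H]1OC(C)=O` gives 94.2%, and compound 3 `O=c1[nH]c(=O)n([C@H]2C[C@H](O)[C@@H](CO)O2)cc1-c1cn(Cc2ccccc2)nn1` gives 95.6%. Compound 1 stands lowest of the three; the nearest number is that of compound 2, which lies higher by a gap beyond the scatter, and the number of compound 3 lies higher still, also beyond the scatter. For the measured compounds named here, compounds 2 and 3 differ from compound 1 in more than one place, so no single step between measured compounds is available to lean on.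

Compound 4 `CC(=O)OC[C@H]1O[C@@H](n2cc(-c3cc(-c4ccc(C(C)C)cc4)no3)c(=O)[nH]c2=O)C[C@@H]1OC(C)=O` is not yet measured in this assay. It differs from compound 1 in one place: isopropyl in place of butyl on an aromatic carbon The change is a shortening of a chain on an aromatic carbon of a six-membered aromatic ring of carbon only, para to a large group, by one carbon; the rest of the molecule is unchanged.

Going by the values given here, with no comparable step in hand, the expectation for the move from compound 1 to compound 4 is a step of a number 4.2 percentage points higher from compound 1 to compound 4 (within the scatter), that is, none beyond the scatter, in either direction. Compound 4 is accordingly estimated at 44% in this assay, with a range from 24% to 68%.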

Compound 4, a percentage reported as inhibition, at one concentration (the size of the read-out at that concentration, not a potency): 56.4%
Estimate against measurement, compound 4: 12.4 percentage points below; measured number inside the range.
By their numbers in this assay, from the lowest: compound 1; then compound 4; then compounds 2 and 3 (each within the scatter of the next).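

In this assay, the change from 4-butylphenyl to 4-isopropylphenyl gives a modest step of a number 16.6 percentage points higher from compound 1 to compound 4 (beyond the scatter) with the rest of the molecule unchanged. For the compounds shown here, the group on this aromatic carbon, para to a large group, therefore has a readable bearing on the number, and this is the first comparison that isolates one place, which the three earlier compounds could not offer. Nothing at hand accounts for the size or direction of this step.

The step combines the loss of one carbon with a change from a straight chain to a branched one, and a single pair cannot separate the two; a straight propyl chain at this position would speak to that, while a hexyl chain or an amine would show how far the trend extends, if there is one. Also open, from the compounds shown here alone, is whether the same change gives a similar step when free hydroxyl groups stand in place of the acetate esters on the shared core.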